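The compounds below may be only part of what the source reports. "The series", "measured", "known", "first", "only" and "open" are said of these compounds alone.

Working notes on the series. Compound 1 `CNCc1cc(-c2cccnc2F)n(S(=O)(=O)c2ccccn2)c1`, compound 2 `CNCc1cn(S(=O)(=O)c2ccoc2)c(-c2cccnc2F)c1F`, compound 3 `CNCc1cn(S(=O)(=O)c2cccc(C)n2)c(-c2cccnc2F)c1F` and compound 4 `CNCc1cn(S(=O)(=O)c2ccc(C)nc2)c(-c2cccnc2F)c1F` share one core and differ in the group on the sulfonyl sulfur. In an ADME assay on the whole organism (plasma, Rattus norvegicus, strain Sprague-Dawley) for pharmacokinetics, read by LC-MS, using cassette dosing, at a dose of 0.2 mg/kg by the intravenous route (a lower number here means less compound in the circulation, a higher number more compound in the circulation at the dose given), compound 1 has "not determined" (no result reported). In this assay compound 2 gives 41 ng.h/mL and compound 3 gives 41 ng.h/mL. Within the data shown here, the one measured step, no change at the digits printed from compound 2 to compound 3 (within the scatter), lies within the scatter. Compound 3 thus stands level with compound 2, with one further entry lacking a number. Compound 4 differs from compound 3 by 6-methylpyridin-3-yl in place of 6-methylpyridin-2-yl on a sulfonyl sulfur; the two have the same atoms, joined differently. Among the measured compounds shown here, with the only measured step on this sulfur showing no change, no step beyond the scatter is expected for compound 4. Compound 4 is estimated at 41 ng.h/mL, with a range of 20 ng.h/mL to 85 ng.h/mL, an expected step of no change at the digits printed from compound 3 to compound 4 (within the scatter).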

Compound 4, area under the concentration-time curve: 41 ng.h/mL
Estimate against measurement, compound 4: no gap at the digits printed; the range from low to high includes it.
By their numbers in this assay, from the lowest: compounds 2, 3 and 4 (each within the scatter of the next).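

In this assay, 6-methylpyridin-3-yl in place of 6-methylpyridin-2-yl on the sulfonyl sulfur gives no change at the digits printed from compound 3 to compound 4 (within the scatter), and 6-methylpyridin-3-yl in place of furan-3-yl gives no change at the digits printed from compound 2 to compound 4 (within the scatter). This position thus now holds a pair with the same atoms, joined differently, as well as a pair of different rings, and neither change separates the compounds. Nothing available explains this absence of a step. On these data alone, whether a group of another kind on this sulfur, such as an amine, a carboxylic acid or a longer chain, would give a step beyond the scatter remains open.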